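The compounds below may be only part of what the source reports. "The series", "measured", "known", "first", "only" and "open" are said of these compounds alone.

Among the compounds with values here, the shared core of compound 2 `CCOC(=O)Nc1cccc2c1CN(C)CC2c1ccccc1` carries a substituent on a carbonyl carbon, and in a functional assay on the whole organism for inhibition of sodium-dependent dopamine transporter (Mus musculus) (a higher number here means that more compound is needed for the effect, a lower number that less compound is needed), compound 2 gives 2.5 mg/kg, the lowest of the three numbers measured so far. Compound 1 `CCCCNC(=O)Nc1cccc2c1CN(C)CC2c1ccccc1` gives 69 mg/kg, and compound 3 `CCOC(=O)Nc1cccc2c1CN(C)CC2c1ccc(Cl)cc1` gives 21 mg/kg. The change at the carbonyl carbon, a 28-fold lower number from compound 1 to compound 2 (1.44 log units; beyond the scatter), was large, while the change on the aromatic ring, an 8.4-fold higher number from compound 2 to compound 3 (0.92 log units; beyond the scatter), was modest. Compound 4 `CCNCC(=O)Nc1cccc2c1CN(C)CC2c1ccccc1` differs from compound 2 in one place: (ethylamino)methyl in place of ethoxy on a carbonyl carbon. Within the data shown here, only the step from compound 1 to compound 2 concerns the same place, and there the swap of a nitrogen-bearing group for ethoxy brought the number far down. Going back the other way, with a nitrogen-bearing group again entering at the carbonyl carbon, points toward a higher number for compound 4, although the entering group is not the one that left in compound 1, so the size is uncertain. Compound 4 is therefore expected to give 15 mg/kg, with a range from 4 mg/kg to 60 mg/kg. The expected step, a 6.0-fold higher number from compound 2 to compound 4 (0.78 log units; beyond the scatter), would be upward and modest to large.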

Compound 4, dose for half-maximal effect: about 60 mg/kg
Estimate against measurement, compound 4: 4.0-fold (0.60 log units) below, and the stated range covers the measured number.
By their numbers in this assay, from the lowest: compound 2; then compound 3; then compounds 4 and 1 (each within the scatter of the next).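

In this assay, placing (ethylamino)methyl instead of ethoxy on the carbonyl carbon gives a 24-fold higher number from compound 2 to compound 4 (1.38 log units; beyond the scatter), so a second nitrogen-bearing group also lies far from the ethoxy compound, not only butylamino. The two nitrogen-bearing groups cannot be told apart in this assay, with a 1.2-fold lower number from compound 1 to compound 4 (0.06 log units; within the scatter), even though they differ in their chains and in where the nitrogen stands. Among the compounds shown, ethoxy is the only group at this place that pairs with the low number, but no measurement here explains the difference between ethoxy and these groups. A propoxy group or a plain propyl chain on the carbonyl carbon would help show whether the low number goes with ethoxy specifically or extends to other groups without nitrogen. As far as these compounds go, whether (ethylamino)methyl would have a similar effect on the chloro-bearing compound 3 also remains open.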